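A few compounds are considered here, and "the series" means these few. Any claim that something is new, unique, unknown or untested is made for them only; others in the source may bear on it.

The measured compounds are compound 1 `O=C(Nc1ccc([N+](=O)[O-])c(C(F)(F)F)c1)c1ccc(Sc2ccc(O)cc2)cc1` with 3580 nM, compound 2 `O=C(Nc1cccc(S(F)(F)(F)(F)F)c1)c1ccc(Sc2ccc(O)cc2)cc1` with 3320 nM, and compound 3 `O=C(Nc1cccc(C(F)(F)F)c1)c1ccc(Sc2ccc(O)cc2)cc1` with 9660 nM, all read in a functional assay on LNCaP cells (Homo sapiens) for antiproliferative activity, read by fluorescence and propidium iodide staining, with a stated time of 96 h; on this read-out higher numbers stand for weaker inhibition and lower numbers for stronger inhibition.

Compound 1 and compound 2 lie within the scatter of each other in this assay, so no order can be read between them. Compound 3 stands apart: the step of a 2.7-fold higher number from compound 1 to compound 3 (0.43 log units; beyond the scatter) is modest but beyond the scatter, and the step of a 2.9-fold higher number from compound 2 to compound 3 (0.46 log units; beyond the scatter) is of similar size. Both of these steps concern the anilide ring of the shared core.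

Compound 4 `O=C(Nc1ccc([N+](=O)[O-])c(C(F)(F)F)c1)c1ccc(S(=O)(=O)c2ccc(O)cc2)cc1` differs from compound 1 in another place: (4-hydroxyphenyl)sulfonyl in place of (4-hydroxyphenyl)sulfanyl on an aromatic carbon. For the measured compounds named here, no measured step touches this part of the molecule, so nothing among the measured compounds bears directly on the change, and the expectation rests on compound 1 alone. Without such evidence, the estimate for compound 4 stays close to compound 1, with a wide range. Compound 4 is expected to give about 4000 nM in this assay, between 1200 nM and 13000 nM. The step this estimate implies is a 1.1-fold higher number from compound 1 to compound 4 (0.05 log units; within the scatter), expected to stay within the scatter.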

Compound 4, half-maximal inhibitory concentration: 4960 nM
Beside the measured number, compound 4's estimate is 1.2-fold (0.09 log units) below it; the measured number falls inside the stated range.
By their numbers in this assay, from the lowest: compounds 2, 1, 4 and 3 (each within the scatter of the next, the first and the last beyond it).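

In this assay, the swap of (4-hydroxyphenyl)sulfanyl for (4-hydroxyphenyl)sulfonyl on the aromatic carbon gives a 1.4-fold higher number from compound 1 to compound 4 (0.14 log units; within the scatter) and so cannot be told apart from no change. For the compounds shown here, this is the first reading at this place, as the earlier steps all concerned a different part of the shared core. It shows that, on the core of compound 1, the number tolerates the larger sulfonyl group, with its two added double bonds, without a shift beyond the scatter. No evidence beyond these numbers bears on this result.

Open, from the compounds shown here alone, is whether the same swap would also leave the number in place on the cores of compound 2 and compound 3. Also open, going by these compounds, is how a sulfinyl group, an ether oxygen or an amine would read in this same place.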